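Aryl swap on the ring nitrogen: compound 3 to compound 4

This account rests on a few compounds, and the source may have more. Where it says the series, first, only, none or still open, it means among the compounds named here.

Among the measured compounds shown here, compound 3 `O=C(COCc1ccncc1)N1CCN(c2ccc(Cl)cc2)CC1` gives 1300 nM in a functional assay on HEK293 cells for positive allosteric modulation of metabotropic glutamate receptor 5 (Homo sapiens), read by FLIPR and calcium flux (a higher number here means that more compound is needed for the effect, a lower number that less compound is needed), the highest of the three numbers so far. Compound 1 `O=C(COCc1ccccc1)N1CCN(c2ccccc2Cl)CC1` gives 1100 nM, within the scatter of compound 3; compound 2 `O=C(COCc1ccccc1)N1CCN(c2ccc(Cl)cc2)CC1` gives 350 nM, and the gap is a 3.7-fold higher number from compound 2 to compound 3 (0.57 log units; beyond the scatter). Compound 4 `O=C(COCc1ccncc1)N1CCN(c2ccc(F)cc2F)CC1` differs from compound 3 in one place: 2,4-difluorophenyl in place of 4-chlorophenyl on an amine nitrogen in a ring. For the measured compounds named here, the only measured step that touches the aryl on the ring nitrogen is a 3.1-fold lower number from compound 1 to compound 2 (0.50 log units; beyond the scatter), a modest shift between two chlorophenyl patterns. Going by the values given here, no step here swaps chlorine for fluorine, and no measured compound carries two halogens on that ring, so the ground is thin. The 2,4-difluorophenyl pattern recalls the 2-chlorophenyl of compound 1 as much as the 4-chlorophenyl of compound 2, and compound 1 sits above compound 2 by a 3.1-fold lower number from compound 1 to compound 2 (0.50 log units; beyond the scatter). A modest rise in this assay, or none beyond the scatter, is therefore expected. Compound 4 is estimated at 1900 nM, range 600 nM to 6000 nM, the expected step being a 1.5-fold higher number from compound 3 to compound 4 (0.16 log units; within the scatter).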

Compound 4, half-maximal effective concentration: 4600 nM
For compound 4 the middle estimate is 2.4-fold (0.38 log units) below the measured one, and the stated range covers the measured number.
By their numbers in this assay, from the lowest: compound 2; then compounds 1 and 3 (each within the scatter of the next); then compound 4.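

In this assay the step is a 3.5-fold higher number from compound 3 to compound 4 (0.55 log units; beyond the scatter) and so the aryl on the amine nitrogen in the ring still moves the number with pyridin-4-yl on the chain, whereas the earlier aryl step was read only with phenyl there. Among the compounds shown here, this is also the first step that changes the halogen itself and the first with two halogens on that ring, and it comes with no change in the counted hydrogen-bond donors or acceptors and no net charge on either group. No measurement at hand accounts for the rise.

Open, on these data alone, is which part of the change carries the step: 4-fluorophenyl and 2,4-dichlorophenyl would separate the kind of halogen from the number of halogens. Also open, as far as these compounds go, are 2,4-difluorophenyl with phenyl in place of pyridin-4-yl, and a methoxy group on that ring.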